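Same side-chain swap on two different cores

The source may hold more compounds than are shown below. What is called first, only, known or untested is meant among the compounds shown, and "the series" means these compounds.

The study compares two pairs of compounds that share one structural change. Compound 2 `CC1=C(C)C(=O)c2nn(Cc3ccccc3)nc2C1=O` and compound 1 `COC(=O)Cn1nc2c(n1)C(=O)C(C)=C(C)C2=O` sit on a common core, and differ only in a methoxycarbonyl in place of phenyl on a saturated chain carbon bound to an aromatic nitrogen. In a functional assay on HeLa cells (Homo sapiens) for inhibition, read by colorimetric assay, with a stated time of 72 h (on this read-out lower numbers stand for an effect already at smaller amounts and higher numbers for an effect only at larger amounts of compound), compound 2 gives 0.8 ug/mL, and in this assay compound 1 gives 1 ug/mL. The step between them is a 1.3-fold higher number from compound 2 to compound 1 (0.10 log units; within the scatter), so the two numbers stand close together.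

Compound 3 `Cc1cc2c(cc1C)[n+]([O-])nn2Cc1ccccc1` rests on a different core, and the difference between the two cores is not broken down here. In this assay compound 3 reaches only a limit, > 100 ug/mL, which is a boundary of the assay and not a number, as the limit of > 100 ug/mL in this assay, at which 1 of the 3 values shown sits, records.

Compound 4 `COC(=O)Cn1n[n+]([O-])c2cc(C)c(C)cc21`, not yet measured, carries the same change as the first pair, a methoxycarbonyl in place of phenyl on a saturated chain carbon bound to an aromatic nitrogen. Since this change produced a 1.3-fold higher number from compound 2 to compound 1 (0.10 log units; within the scatter) on the other core, the expected shift on this core is a step that the limit leaves unreadable from compound 3 to compound 4. Compound 4 is therefore expected to remain near the limit, with an estimate of 150 ug/mL, ranging from 50 ug/mL to 500 ug/mL, and most likely the assay will again report only a limit.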

Compound 4, concentration for half-maximal effect: > 100 ug/mL
Compound 4 gave a limit, no number; the forecaster's own chance of this, stated with the estimate: 75%; the middle value is on the limit's open side.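

In this assay, for the compounds shown here, compound 3 and compound 4 each give a limit of the assay and not a number, so no step between them can be read. The compounds shown leave open whether methoxycarbonyl in place of phenyl on a saturated chain carbon bound to an aromatic nitrogen changes the read-out on the core of compound 3 at all, and in which direction.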